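A few compounds are considered here, and "the series" means these few. Any claim that something is new, unique, unknown or untested is made for them only; others in the source may bear on it.

Compound 1 `COc1ccc(Nc2ncc(C(F)(F)F)c(N3Cc4cccc(N(C)S(C)(=O)=O)c4C3)n2)cc1C(F)(F)F` gives > 30000 nM (a limit of the assay)
Compound 2 `Cc1ccc(Nc2ncc(C(F)(F)F)c(N3Cc4cccc(N(C)S(C)(=O)=O)c4C3)n2)cc1C` gives > 30000 nM (a limit of the assay)
Compound 3 `CN(c1cccc2c1CN(c1nc(Nc3ccc(C(F)(F)F)cc3)ncc1C(F)(F)F)C2)S(C)(=O)=O` gives > 30000 nM (a limit of the assay)

All three results come from a functional assay on OVCAR-3 cells (Homo sapiens) for antiproliferative activity, read by spectrophotometry, with a stated time of 2 days (on this read-out lower numbers stand for stronger inhibition of growth and higher numbers for weaker inhibition of growth), and are limits rather than numbers. In this assay compound 3 stands at > 30000 nM and this too is only a limit. The wider picture is the limit of > 30000 nM in this assay, at which 3 of the 3 values shown sit, and so compound 3 cannot be ranked against the others.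

Compound 4 `Cc1cc(C)cc(Nc2ncc(C(F)(F)F)c(N3Cc4cccc(N(C)S(C)(=O)=O)c4C3)n2)c1` keeps the shared core and changes one group: 3,5-dimethylphenyl in place of 4-(trifluoromethyl)phenyl on a nitrogen on an aromatic ring. Here 3,5-dimethylphenyl takes the place of 4-(trifluoromethyl)phenyl on a nitrogen on an aromatic ring.

Three measured steps change this same place: a step that the two limits leave unreadable from compound 1 to compound 2 and a step that the two limits leave unreadable from compound 1 to compound 3 and a step that the two limits leave unreadable from compound 2 to compound 3. None has a size that can be read. Compound 2, the closest relative with its 3,4-dimethylphenyl group, sits at the limit > 30000 nM in this series.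

With no readable step to draw on, no change beyond the scatter is expected and no direction can be given. The expected step is a number no higher from compound 3 to compound 4 (the limit leaves the size open) and it is only an estimate. Compound 4 is estimated at 30000 nM with an expected range from 10000 nM to 50000 nM and the result will probably be another limit.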

Compound 4, concentration for 50% growth inhibition: > 30000 nM
Compound 4 was reported as a limit; the forecaster's own chance of this, stated with the estimate: 85%; the middle value lies on the limit itself.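

Compound 4 is also reported only as a limit, so its steps from compound 1, compound 2 and compound 3 cannot be read: the limit of > 30000 nM in this assay, at which 4 of the 4 values shown sit.

The compounds shown leave open how strongly any of them inhibits growth, and whether changing the group on the nitrogen matters at all.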